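Methoxy for Chloro: Expected Paw Edema Inhibition of Compound 3

The source may report more compounds than this note shows. Statements on the series, on what has been measured and on what is new or still open speak of the compounds shown alone.

Compound 1 `COc1ccc(/C=C/C(=O)c2ccc(NC(=O)CO[N+](=O)[O-])cc2)cc1`: 49%
Compound 2 `C/C(=N/O)c1ccc(OCC(=O)Nc2ccc(C(=O)/C=C/c3ccc(Cl)cc3)cc2)cc1`: 54%

Of the compounds shown here, two have been measured in a functional assay on the whole organism (strain albino) for inhibition, with Rattus norvegicus as the target, read by paw edema, with stated times of 30 min and 2 h, at a dose of 100 mg/kg by the oral route; a lower number here means less inhibition, a higher number more inhibition at the dose given (going by the name of the read-out). Compound 1 gives 49%, and compound 2 gives 54%. Compound 2 holds the higher of the two numbers, but its gap to compound 1 lies within the usual scatter, so the two cannot be told apart. Compound 3 `COc1ccc(/C=C/C(=O)c2ccc(NC(=O)COc3ccc(/C(C)=N\O)cc3)cc2)cc1` has not been measured. It differs from compound 2 in one place: methoxy in place of chloro on an aromatic carbon. For the measured compounds named here, no measured pair shows this change, so its size in this assay is unknown. The step of a number 2 percentage points lower from compound 2 to compound 3 (within the scatter) is expected to stay within the scatter. The estimate for compound 3 is 52%, between 35% and 68%.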

Compound 3, a percentage reported as inhibition, in the whole organism at one dose (the size of the read-out at that dose, not a potency): 41%
Estimate against measurement, compound 3: 11 percentage points above; the range from low to high includes it.
By their numbers in this assay, from the lowest: compounds 3, 1 and 2 (each within the scatter of the next, the first and the last beyond it).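

In this assay, methoxy in place of chloro on the aromatic carbon gives a number 13 percentage points lower from compound 2 to compound 3 (beyond the scatter), so inhibition at the dose given responds to the group at this position. With methoxy in place, the group of 10 heavy atoms in place of the group of 3 heavy atoms gives a number 8 percentage points lower from compound 1 to compound 3 (within the scatter), a change that cannot be told from none. Nothing here gives a reason for the step from chloro to methoxy. From the compounds shown here alone, whether a hydroxyl, an amine or a fluoro at this position would hold inhibition nearer to chloro or to methoxy stays open.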